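Methylsulfonyl for methoxy in a cytotoxicity series without readable values

The source may hold more compounds than are shown below. What is called first, only, known or untested is meant among the compounds shown, and "the series" means these compounds.

This account follows the step from compound 2 `COc1cccc(-c2ccc(C(=O)N(Cc3cccc(OCCCCCC(=O)O)c3)C(C)C)cc2)c1` to the as yet unmeasured compound 4 `CC(C)N(Cc1cccc(OCCCCCC(=O)O)c1)C(=O)c1ccc(-c2cccc(S(C)(=O)=O)c2)cc1` in an ADME assay on Raji cells (Homo sapiens) for cytotoxicity, read by CellTiter-Glo and resazurin assay, with a stated time of 72 h; on this read-out higher numbers stand for an effect only at larger amounts of compound and lower numbers for an effect already at smaller amounts. Among the compounds with values here, the three measured members all reach only the limit of this assay. Compound 2 gives > 20900 nM, which is a limit rather than a number. Compound 1 `CC(C)N(Cc1cccc(OCCCCCC(=O)O)c1)C(=O)c1ccc(-c2ccoc2)cc1` gives > 26000 nM, likewise a limit. Compound 3 `COc1cc(F)cc(-c2ccc(C(=O)N(Cc3cccc(OCCCCCC(=O)O)c3)C(C)C)cc2)c1` gives > 26000 nM, again a limit. Because all three values sit at the limit of > 20900 nM in this assay, at which 1 of the 3 values shown sits, or at the limit of > 26000 nM in this assay, at which 2 of the 3 values shown sit, the steps between them cannot be read: a step that the two limits leave unreadable from compound 1 to compound 2, a step that the two limits leave unreadable from compound 1 to compound 3 and a step that the two limits leave unreadable from compound 2 to compound 3 each leave their size open, so compound 2 stands nowhere in particular among them, only at the limit with the other two.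

The change to compound 4 is methylsulfonyl in place of methoxy on an aromatic carbon. Within the data shown here, of the measured steps, the one from compound 2 to compound 3 also alters the same ring by a small group, and it too was unreadable, so no measured step gives a size in either direction for this change. With three limits and no readable step, the expectation is that compound 4 again shows an effect only at the top of the tested range, and the step that the limit leaves unreadable from compound 2 to compound 4 is estimated to stay within the scatter. Compound 4 is therefore estimated at 26000 nM, with a range from 8000 nM to 60000 nM.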

Compound 4, half-maximal effective concentration: > 26000 nM
Compound 4 gave a limit, no number; the forecaster's own chance of this, stated with the estimate: 85%; the middle value lies on the limit itself.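

In this assay compound 4 gives > 26000 nM, a limit and not a number, so its steps to compound 1, compound 2 and compound 3 cannot be read. The compounds shown leave open at what concentration any of them would show an effect on these cells, and whether methylsulfonyl and methoxy differ there at all.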